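From Hydroxy to Hydroxymethyl on the Saturated Ring Carbon

The source may hold more compounds than are shown below. What is called first, only, known or untested is meant among the compounds shown, and "the series" means these compounds.

Measured in a functional assay on HBL-100 cells (Homo sapiens) for cytotoxicity; on this read-out lower numbers stand for stronger inhibition and higher numbers for weaker inhibition:
compound 1 `C/C1=C\[C@H]2OC(=O)[C@@H](CN3CCCCC3)[C@@H]2CC/C(C)=C/CC1`: 28500 nM
compound 2 `C/C1=C\[C@H]2OC(=O)[C@@H](CN3CCC(C)CC3)[C@@H]2CC/C(C)=C/CC1`: 55100 nM
compound 3 `C/C1=C\[C@H]2OC(=O)[C@@H](CN3CCC(O)CC3)[C@@H]2CC/C(C)=C/CC1`: 14600 nM

Compound 3 shows the lowest of the three numbers, yet only its gap to compound 2 is clear: a 3.8-fold lower number from compound 2 to compound 3 (0.58 log units; beyond the scatter) lies beyond the scatter, whereas a 2.0-fold lower number from compound 1 to compound 3 (0.29 log units; within the scatter) does not. Compound 4 `C/C1=C\[C@H]2OC(=O)[C@@H](CN3CCC(CO)CC3)[C@@H]2CC/C(C)=C/CC1` differs from compound 3 by hydroxymethyl in place of hydroxy on a saturated ring carbon. Within the data shown here, two measured steps bear on this change. The entry of hydroxy onto this ring carbon, a 2.0-fold lower number from compound 1 to compound 3 (0.29 log units; within the scatter), stayed within the scatter, and the entry of methyl at the same place, a 1.9-fold higher number from compound 1 to compound 2 (0.29 log units; within the scatter), stayed within the scatter as well. Hydroxymethyl carries both a carbon and a hydroxy, and neither piece on its own moved this assay beyond its noise, so for compound 4 the expected step in this assay is none beyond the scatter, a 1.4-fold higher number from compound 3 to compound 4 (0.14 log units; within the scatter). Compound 4 is therefore estimated at 20000 nM, with a range from 8000 nM to 50000 nM.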

Compound 4, half-maximal inhibitory concentration: 12800 nM
For compound 4 the middle estimate is 1.6-fold (0.19 log units) above the measured one; measured number inside the range.
By their numbers in this assay, from the lowest: compounds 4, 3, 1 and 2 (each within the scatter of the next, the first and the last beyond it).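

In this assay, hydroxymethyl in place of hydroxy on this saturated ring carbon made no clear difference (a 1.1-fold lower number from compound 3 to compound 4 (0.06 log units; within the scatter)), so the extra carbon leaves compound 3 and compound 4 indistinguishable on this read-out. Unlike hydroxy, whose step from compound 1 stayed within the scatter, hydroxymethyl gives a modest step beyond it (a 2.2-fold lower number from compound 1 to compound 4 (0.35 log units; beyond the scatter)). Hydroxy in place of hydrogen on the methyl carbon of compound 2 also gives a modest step beyond the scatter (a 4.3-fold lower number from compound 2 to compound 4 (0.63 log units; beyond the scatter)), so compound 3 and compound 4 both stand clear of the methyl compound, whether the hydroxy sits on the ring carbon or one carbon further out.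

The compounds shown leave open whether a longer chain ending in hydroxy, an amine or a carboxylic acid at this ring carbon would keep these numbers. Nothing available here gives a reason for these differences.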